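Cytotoxicity notes on a styryl-isoxazole ester series

A few compounds are considered here, and "the series" means these few. Any claim that something is new, unique, unknown or untested is made for them only; others in the source may bear on it.

Working notes on a small set sharing one core. Compound 1 is `CCOC(=O)c1cc(/C=C/c2ccccc2)on1` and compound 2 is `CCOC(=O)c1cc(/C=C/c2ccc(OCc3ccccc3)cc2)on1`; compound 3, `CCOC(=O)c1cc(/C=C/c2cccc(N)c2)on1`, has not yet been run. The read-out of interest is an ADME assay on Vero cells (Chlorocebus sabaeus) for cytotoxicity, with a stated time of 72 h (a higher number here means a weaker inhibitor, a lower number a stronger inhibitor), given as a half-maximal inhibitory concentration.

Compound 1 stands without a number: in this assay compound 1 gives "not determined" (no result reported). Going by the values given here, the only value in hand is a limit of the assay rather than a number: in this assay compound 2 gives > 128000 nM. Among the compounds with values here, because of the limit of > 128000 nM in this assay, at which 1 of the 2 values shown sits, the one value shown sits at the upper edge of what the assay reports, and no step between measured compounds can be drawn.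

The change from compound 1 to compound 3 is amino in place of hydrogen on an aromatic carbon. Within the data shown here, with no measured step to lean on, the expectation in this assay is no shift beyond the usual scatter, in either direction, and a weak result like that of compound 2. For compound 3 in this assay the estimated value is 100000 nM, expected to fall between 30000 nM and 200000 nM.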

Compound 3, half-maximal inhibitory concentration: > 128000 nM
Compound 3 was reported as a limit; the forecaster's own chance of this, stated with the estimate: 60%; middle value at least 1.2-fold (0.10 log units) away from the limit.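

In this assay compound 3 gives > 128000 nM, which is a limit of the assay and not a number. No new step can be read for compound 1, compound 2 or compound 3, because the values offer no numbers to compare: the limit of > 128000 nM in this assay, at which 2 of the 3 values shown sit.

The compounds shown leave open whether any change on the shared core gives a measurable value in this assay.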